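Replacing a Diol Amide with a Hydroxypyrrolidine Amide

A few compounds are considered here, and "the series" means these few. Any claim that something is new, unique, unknown or untested is made for them only; others in the source may bear on it.

Two compounds have been measured in an ADME assay on the whole organism (plasma, Mus musculus) for pharmacokinetics, read by LC-MS, at a dose of 30 mg/kg by the oral route; on this read-out higher numbers stand for higher exposure at the dose given and lower numbers for lower exposure:
Compound 1 `CONC(=O)c1cccc(Oc2cc(CN)cc(C(F)(F)F)n2)c1` gives 630 nM.
Compound 2 `NCc1cc(Oc2cccc(C(=O)NC[C@@H](O)CO)c2)nc(C(F)(F)F)c1` gives 2770 nM.

For the measured compounds named here, the only measured step is a 4.4-fold higher number from compound 1 to compound 2 (0.64 log units; beyond the scatter), so compound 2 stands highest of the two numbers, and compound 1 is its nearest neighbour. The next compound, compound 3 `NCc1cc(Oc2cccc(C(=O)N3CC[C@@H](O)C3)c2)nc(C(F)(F)F)c1`, keeps the core of compound 2 and changes one place: 3-hydroxypyrrolidin-1-yl in place of (2,3-dihydroxypropyl)amino on a carbonyl carbon. Going by the values given here, the one measured step swapped methoxy for 2,3-dihydroxypropyl on an amide-type nitrogen, a different kind of change from this one, in which a ring enters where a chain stood; no measured step bears directly on it. With nothing to guide a direction, the expectation for compound 3 is a step of a 1.1-fold lower number from compound 2 to compound 3 (0.04 log units; within the scatter) in this assay, which is within the scatter. Compound 3 is therefore estimated at 2500 nM, with a range from 900 nM to 7000 nM.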

Compound 3, maximal plasma concentration: 5130 nM
Estimate against measurement, compound 3: 2.1-fold (0.31 log units) below, and the stated range covers the measured number.
By their numbers in this assay, from the lowest: compound 1; then compounds 2 and 3 (each within the scatter of the next).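

In this assay, a ring can stand on this carbonyl carbon in place of a chain without the read-out separating the two (a 1.9-fold higher number from compound 2 to compound 3 (0.27 log units; within the scatter)), even though 3-hydroxypyrrolidin-1-yl carries 1 hydrogen-bond donor where (2,3-dihydroxypropyl)amino carries 3. The gain seen over the methoxyamino group of compound 1 therefore does not depend on the open diol chain, since the ring also stands clear of that group (an 8.1-fold higher number from compound 1 to compound 3 (0.91 log units; beyond the scatter)). No measured evidence explains either step.

It remains open whether the hydroxyl on the ring is needed at all, as neither a plain pyrrolidine nor a ring bearing an amine in its place is among the compounds shown. The opposite stereocentre of the 3-hydroxypyrrolidin-1-yl group and a six-membered piperidine ring are also absent from them.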